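The source may report more compounds than this note shows. Statements on the series, on what has been measured and on what is new or still open speak of the compounds shown alone.

Measured so far in an assay on Prostate gland for inhibition of steroid 5-alpha-reductase (Rattus norvegicus); a lower number here means a stronger inhibitor, a higher number a weaker inhibitor:
compound 1, `C/C(=C\C(=O)Nc1ccccc1OCCCC(=O)O)c1ccc2c(ccn2CC(C)C)c1`, 160 nM
compound 2, `C/C(=C\C(=O)Nc1ccccc1OCCCC(=O)O)c1ccc2c(ccn2C(C(C)C)C(C)C)c1`, 14 nM
compound 3, `C/C(=C\C(=O)Nc1ccccc1OCCCC(=O)O)c1ccc2c(ccn2Cc2ccc(C(C)(C)C)cc2)c1`, 170 nM

Compound 3 stands at the highest of the three numbers in this assay. Its nearest neighbour is compound 1, with a gap that lies within the scatter, so no order between compound 1 and compound 3 can be claimed; compound 2 lies furthest away, with a 12-fold higher number from compound 2 to compound 3 (1.08 log units; beyond the scatter).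

The next compound, compound 4, `C/C(=C\C(=O)Nc1ccccc1OCCCC(=O)O)c1ccc2c(ccn2C(c2ccccc2)C(C)C)c1`, is not yet measured. Against compound 3 the change is 2-methyl-1-phenylpropyl in place of 4-(tert-butyl)benzyl on an aromatic nitrogen.

Among the compounds with values here, two measured steps bear on this change. The step of an 11-fold lower number from compound 1 to compound 2 (1.06 log units; beyond the scatter) shows that placing an isopropyl on the saturated chain carbon bound to the aromatic nitrogen gives a large move to a lower number. The step of a 12-fold higher number from compound 2 to compound 3 (1.08 log units; beyond the scatter) shows the reverse: replacing 1-isopropyl-2-methylpropyl by 4-(tert-butyl)benzyl gives a large move to a higher number. Compound 4 carries 2-methyl-1-phenylpropyl, which combines a phenyl with an isopropyl on the carbon attached to the aromatic nitrogen, so a step toward a lower number in this assay, of a size approaching that seen in the step from compound 1 to compound 2, is expected, a 6.8-fold lower number from compound 3 to compound 4 (0.83 log units; beyond the scatter).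

For compound 4 the estimated value in this assay is 25 nM, with a range from 8 nM to 80 nM.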

Compound 4, half-maximal inhibitory concentration: 25 nM
Compound 4: middle estimate and measured number agree at the digits printed; low and high end bracket the measured number.
By their numbers in this assay, from the lowest: compounds 2 and 4 (each within the scatter of the next); then compounds 1 and 3 (each within the scatter of the next).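

In this assay the saturated chain carbon bound to the aromatic nitrogen takes a phenyl as well as an isopropyl: phenyl in place of hydrogen gives a 6.4-fold lower number from compound 1 to compound 4 (0.81 log units; beyond the scatter), while phenyl in place of isopropyl gives a 1.8-fold higher number from compound 2 to compound 4 (0.25 log units; within the scatter), so no order between the two groups can be claimed. 2-methyl-1-phenylpropyl and 4-(tert-butyl)benzyl each carry one six-membered aromatic ring of carbon only, yet exchanging them gives a 6.8-fold lower number from compound 3 to compound 4 (0.83 log units; beyond the scatter), so the presence of that ring does not by itself set the number, and across these four compounds the two with a second group on that chain carbon, compound 2 and compound 4, lie beyond the scatter from the two without one, compound 1 and compound 3. No measurement at hand gives a reason for these steps.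

Open, on these data alone, is how much of the change between those two groups belongs to the second group on the chain carbon and how much to the tert-butyl, which a plain benzyl on the aromatic nitrogen would help to separate. Also open, as far as these compounds go, is whether that carbon accepts a group of another kind, such as an amine or a carboxylic acid, in place of isopropyl or phenyl.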